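The source may report more compounds than this note shows. Statements on the series, on what has been measured and on what is new or still open speak of the compounds shown alone.

Measured compounds: compound 1 `COc1cccc(CNCc2c(-c3nnc(SC(C)C)n3-c3ccccc3)n(C)c3ccc(F)cc23)c1` with 6.42; compound 2 `CC(C)Sc1nnc(-c2c(CN3CCC(N4CCCC4)CC3)c3ccccc3n2C)n1-c1ccccc1` with 5.16; compound 3 `CC1CCN(Cc2c(-c3nnc(SC(C)C)n3-c3ccccc3)n(C)c3ccccc23)CC1` with 5.96, all in a physicochemical assay for lipophilicity; a higher number here means a more lipophilic compound, a lower number a more polar compound.

Compound 3 stands second highest of the three: compound 1 lies above it and compound 2 below, both beyond the scatter. For the measured compounds named here, the only counted step, a number 0.80 log units higher from compound 2 to compound 3 (beyond the scatter), concerns a different change on a saturated ring carbon and does not directly cover the move to compound 4 `COc1cccc(CNCc2c(-c3nnc(SC(C)C)n3-c3ccccc3)n(C)c3ccccc23)c1`, where ((3-methoxybenzyl)amino in place of 4-methylpiperidin-1-yl on a saturated chain carbon bound to an aromatic carbon). Compound 1 carries the same (3-methoxybenzyl)amino group and gives 6.42, which is the closest guide. An upward step, a number 0.24 log units higher from compound 3 to compound 4 (within the scatter), is therefore expected, and compound 4 is estimated at 6.2, in the range 5.8 to 6.6.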

Compound 4, partition coefficient: 6.27
Compound 4: middle estimate off by 0.07 log units, on the low side; the measured number falls inside the stated range.
By their numbers in this assay, from the lowest: compound 2; then compound 3; then compounds 4 and 1 (each within the scatter of the next).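

In this assay, (3-methoxybenzyl)amino on a saturated chain carbon bound to an aromatic carbon sits modestly above 4-methylpiperidin-1-yl (a number 0.31 log units higher from compound 3 to compound 4 (beyond the scatter)) and far above 4-(pyrrolidin-1-yl)piperidin-1-yl (a number 1.11 log units higher from compound 2 to compound 4 (beyond the scatter)), so the group at this place sets the number across a wide span. Hydrogen in place of fluoro on an aromatic carbon, by contrast, gives a step within the scatter (a number 0.15 log units lower from compound 1 to compound 4 (within the scatter)). Nothing at hand explains these steps.

Still open, on these data alone, is where a carboxylic acid or a morpholine at the same saturated chain carbon would fall in this assay.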